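From 4-iodophenyl to 3-nitrophenyl on a shared core

The source may report more compounds than this note shows. Statements on the series, on what has been measured and on what is new or still open speak of the compounds shown alone.

In a functional assay on L1210 cells (Mus musculus) for antiproliferative activity (on this read-out lower numbers stand for stronger inhibition and higher numbers for weaker inhibition), compound 1 `COc1cc(C(=O)c2sc(-c3ccc(Br)cc3)cc2N)cc(OC)c1OC` gives 100 nM and compound 2 `COc1cc(C(=O)c2sc(-c3ccc(Cl)cc3)cc2N)cc(OC)c1OC` gives 93 nM. Compound 3 `COc1cc(C(=O)c2sc(-c3ccc(I)cc3)cc2N)cc(OC)c1OC` has the highest number of the three at 400 nM. Compound 4 `COc1cc(C(=O)c2sc(-c3cccc([N+](=O)[O-])c3)cc2N)cc(OC)c1OC` carries 3-nitrophenyl in place of 4-iodophenyl on an aromatic carbon, next to the ring sulfur: 3-nitrophenyl in place of 4-iodophenyl on an aromatic carbon.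

Only the halogen steps bear on this change. Exchanging bromo for chloro gives a 1.1-fold lower number from compound 1 to compound 2 (0.03 log units; within the scatter), whereas the two steps to iodo are modest: a 4.0-fold higher number from compound 1 to compound 3 (0.60 log units; beyond the scatter) and a 4.3-fold higher number from compound 2 to compound 3 (0.63 log units; beyond the scatter). Within the data shown here, none of the measured compounds carries a nitro group or a 3-substituted phenyl, so these steps offer only a rough guide to size. Since compound 3 sits at the top of the measured span, a small move to a lower number seems more likely than a further rise. The expected step is a 1.6-fold lower number from compound 3 to compound 4 (0.20 log units; within the scatter), which is no larger than the iodo steps. For compound 4 the estimated value is 250 nM, with an expected range from 70 nM to 1000 nM.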

Compound 4, half-maximal inhibitory concentration: 11 nM
The estimate for compound 4 lay 23-fold (1.36 log units) above the measured number, and the stated range ends above it.
By their numbers in this assay, from the lowest: compound 4; then compounds 2 and 1 (each within the scatter of the next); then compound 3.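

The aromatic carbon next to the ring sulfur proves able to give far lower numbers than the halogen compounds suggested: in this assay the change from 4-iodophenyl to 3-nitrophenyl is a large one, a 36-fold lower number from compound 3 to compound 4 (1.56 log units; beyond the scatter). The result does not rest on compound 3 alone, since the 4-bromophenyl and 4-chlorophenyl compounds also lie well above the new compound, with a 9.1-fold lower number from compound 1 to compound 4 (0.96 log units; beyond the scatter) and an 8.5-fold lower number from compound 2 to compound 4 (0.93 log units; beyond the scatter). The halogens therefore did not mark the lower end at this position, and compound 4 now holds the lowest number of the four. Nothing at hand explains this fall.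

Because the nitro group and the 3-substitution enter together, the compounds shown cannot separate them. 4-Nitrophenyl and 3-chlorophenyl would do so, and 3-aminophenyl would test whether the nitro group itself matters.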